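The source may hold more compounds than are shown below. What is called first, only, known or untested is meant among the compounds shown, and "the series" means these compounds.

Compound 1 `CCc1c(C(N)C(=O)O)cnn1O` and compound 2 `CCCc1c(C(N)C(=O)O)cnn1O` share a core with compound 3 `CCCCc1c(C(N)C(=O)O)cnn1O`, each carrying a different chain on it. In a functional assay on CHO cells for agonist activity at metabotropic glutamate receptor 2 (Rattus norvegicus), read by cAMP accumulation (on this read-out lower numbers stand for an effect already at smaller amounts and higher numbers for an effect only at larger amounts of compound), compound 1 gives 57000 nM; 56200 nM (2 entries), and in this assay compound 2 gives 72000 nM; 67600 nM (2 entries); the two values lie close together. For compound 3 this assay reports only a limit, > 1000000 nM, and not a number, so compound 3 stands at the edge of what the read-out can resolve. The step to compound 4 `CCCCCc1c(C(N)C(=O)O)cnn1O` is the same kind of lengthening already seen along the series: methyl in place of hydrogen on a saturated chain carbon, four bonds along the chain from an aromatic carbon. Among the measured compounds shown here, no measured step between neighbouring compounds is available to set its size, so the expectation rests on what the three numbers show. In this assay compound 4 is expected to give 2000000 nM, with a range from 500000 nM to 10000000 nM. The step that the limit leaves unreadable from compound 3 to compound 4 is estimated as a further weakening, and compound 4 is expected most likely to return only a limit in this assay, as compound 3 did with the limit of > 1000000 nM in this assay, at which 1 of the 3 values shown sits.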

Compound 4, half-maximal effective concentration: > 1000000 nM
Compound 4: no number, only a limit; the forecaster's own chance of this, stated with the estimate: 85%; the middle value does not contradict the limit.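

In this assay compound 4 gives only a limit, > 1000000 nM. Compound 3 also stands at a limit, so no new step can be read between compound 3 and compound 4. The compounds shown leave open how these two actually compare in this assay.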